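This account rests on a few compounds, and the source may have more. Where it says the series, first, only, none or still open, it means among the compounds named here.

Compound 1 `CCn1c(-c2cnc(C)nc2)nc2c(N[C@H]3CCN(C(=O)C4CCC4)C3)ncnc21`: 0.5 L/kg
Compound 2 `CCC(=O)N1CC[C@H](Oc2ncnc3c2nc(-c2cnc(C)nc2)n3CC)C1`: 1.2 L/kg
Compound 3 `CCn1c(-c2ccc(C(F)(F)F)nc2)nc2c(O[C@H]3CCN(C(=O)N4CC(OC)C4)C3)ncnc21`: 0.2 L/kg

These three compounds were measured in an ADME assay (Rattus norvegicus, strain Wistar Han) for pharmacokinetics; a lower number here means that more of the compound stays in the plasma, a higher number that more of the compound sits outside the plasma. Compound 2 gives the highest number of the three; compound 1 sits nearest to it and compound 3 furthest away, and both gaps lie beyond the usual scatter of repeated measurements. Compound 4 `CCn1c(-c2cnc(C)nc2)nc2c(O[C@H]3CCN(C(=O)[C@H]4C[C@@H](OC)C4)C3)ncnc21` has not been measured yet. It differs from compound 2 in one place: 3-methoxycyclobutyl in place of ethyl on a carbonyl carbon. The shared core and the rest of the molecule stay the same, so any shift in the number would go with this single change. Within the data shown here, no pair of measured compounds shows this exact change, so the size of the step can only be estimated. Among the measured compounds shown here, the only guide is that the two other compounds, which differ from compound 2 in several places, both sit lower: compound 1 gives 0.5 L/kg and compound 3 gives 0.2 L/kg. A modest downward step a 1.5-fold lower number from compound 2 to compound 4 (0.18 log units; within the scatter) is therefore expected, one that may not clear the scatter. Compound 4 is estimated at 0.8 L/kg, most likely between 0.4 L/kg and 1.6 L/kg.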

Compound 4, volume of distribution: 0.5 L/kg
For compound 4 the middle estimate is 1.6-fold (0.20 log units) above the measured one; the range from low to high includes it.
By their numbers in this assay, from the lowest: compound 3; then compounds 1 and 4 (each within the scatter of the next); then compound 2.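

In this assay the group on the carbonyl carbon proves able to move the number by itself: with the shared core and the rest of the molecule unchanged, 3-methoxycyclobutyl in place of ethyl gives a 2.4-fold lower number from compound 2 to compound 4 (0.38 log units; beyond the scatter). The other compounds differ from compound 2 in several places, so their lower numbers could not be tied to any one part, whereas this step belongs to a single change. No measurement shown bears on the reason for this step.

From the compounds shown here alone, it remains open whether the step goes with the four-membered ring, with the methoxy group or with the added atoms in general. Going by these compounds, it is also open how a longer chain such as butyl, or a group carrying an amine or a carboxylic acid, would behave on the same carbonyl carbon.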